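The compounds below may be only part of what the source reports. "The series", "measured", "known", "first", "only" and "open" are said of these compounds alone.

Working notes on the series.

Compound 1 `CCn1c(SCC(=O)Nc2ccc(/C(C)=N/O)cc2)nnc1-c1ccc(OC)c(OC)c1` is the reference point. Among the compounds with values here, in a functional assay on the whole organism (strain albino) for inhibition, with Rattus norvegicus as the target, read by paw edema, with stated times of 30 min and 3 h, at a dose of 0.28 mmol/kg by the oral route (a higher number here means more inhibition at the dose given (going by the name of the read-out), a lower number less inhibition), compound 1 gives 66%, the second highest of the three numbers so far. Compound 2 `CCn1c(SCC(=O)Nc2ccc(/C(C)=N/O)cc2)nnc1-c1ccc(OC)cc1` gives 60% in this assay, and compound 3 `CCn1c(SCC(=O)Nc2ccc(/C(C)=N/O)cc2)nnc1-c1cc(OC)c(OC)c(OC)c1` gives 70%. Both known steps concern the methoxy pattern on the aryl ring attached to the shared core: a number 6 percentage points lower from compound 1 to compound 2 (within the scatter) and a number 4 percentage points higher from compound 1 to compound 3 (within the scatter). Neither reaches beyond the scatter, so across these three compounds the number has stayed essentially flat.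

Compound 4 `CCn1c(SCC(=O)Nc2ccc(C(C)=O)cc2)nnc1-c1ccc(OC)c(OC)c1` keeps the methoxy pattern of compound 1 and alters the other end of the molecule: a group of 3 heavy atoms (2 carbon, 1 oxygen; no ring) in place of a group of 4 heavy atoms (2 carbon, 1 nitrogen, 1 oxygen; no ring), on an aromatic carbon, the place being on an aromatic carbon of a six-membered aromatic ring of carbon only, para to a large group. Within the data shown here, no measured step touches this position; the two steps on record, both within the scatter, are on a different ring and so bear on it only indirectly, showing that the number has so far stayed level through small changes. There is thus no basis for expecting a shift beyond the scatter in this assay, in either direction; the expected step is a number 4 percentage points lower from compound 1 to compound 4 (within the scatter). Compound 4 is therefore estimated at 62%, with a range of 48% to 76%.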

Compound 4, a percentage reported as inhibition, in the whole organism at one dose (the size of the read-out at that dose, not a potency): 62%
Compound 4: the middle estimate sits on the measured number at the digits printed, and the stated range covers the measured number.
By their numbers in this assay, from the lowest: compounds 2, 4, 1 and 3 (each within the scatter of the next).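

Acetyl in place of the group of 4 heavy atoms, on an aromatic carbon of a six-membered aromatic ring of carbon only, para to a large group, gives the first measured step at this position: in this assay it is a number 4 percentage points lower from compound 1 to compound 4 (within the scatter). The earlier steps shown here covered only the methoxy pattern on the other aryl ring, whereas this one shows that the number also stays level when the far end of the molecule changes, even with the loss of the one hydrogen-bond donor of the leaving group and with one hydrogen-bond acceptor in place of two. No measurement at hand bears on the reason for this step.

This single pair leaves open whether a carboxylic acid, an amine or a longer chain at the same position would give a step beyond the scatter in this assay. It also leaves open whether acetyl holds the number level when combined with the methoxy patterns of compound 2 and compound 3, and, with a read-out at one dose only, whether compound 1 and compound 4 would stay level at other doses.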